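From a Fluorophenyl to a Dimethoxyphenyl Group

A few compounds are considered here, and "the series" means these few. Any claim that something is new, unique, unknown or untested is made for them only; others in the source may bear on it.

Of the compounds shown here, two have been measured in an in vitro assay on HEK385-7 cells for displacement of a labelled ligand from prostaglandin D2 receptor 2 (Homo sapiens); on this read-out lower numbers stand for stronger inhibition and higher numbers for weaker inhibition. Compound 1 `O=C(O)Cc1sc(Cc2ccccc2-c2ccccc2)nc1-c1ccc(Cl)cc1` gives 41 nM in this assay, while compound 2 `O=C(O)Cc1sc(C(c2ccccc2)c2ccccc2)nc1-c1cccc(F)c1` gives 2.9 nM. Compound 2 therefore holds the lower of the two numbers, and its gap to compound 1 lies beyond the scatter. Compound 3 `COc1ccc(OC)c(-c2nc(C(c3ccccc3)c3ccccc3)sc2CC(=O)O)c1` has not yet been measured. It differs from compound 2 in one place: 2,5-dimethoxyphenyl in place of 3-fluorophenyl on an aromatic carbon. Among the compounds with values here, no pair of measured compounds shares exactly this change, so nothing in the data shows how this assay responds to it; the only guide is that compound 2 itself sits at a low number. With an untested change of this size, movement in either direction is plausible. The expectation for compound 3 is a modest rise, a step of a 2.8-fold higher number from compound 2 to compound 3 (0.44 log units; beyond the scatter) to an estimated 8 nM, with a range from 2 nM to 40 nM.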

Compound 3, half-maximal inhibitory concentration: > 105 nM
Compound 3 was reported as a limit; the forecaster's own chance of this, stated with the estimate: 3%; middle value at least 13-fold (1.11 log units) from the limit.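

Compound 2's low number does not carry over to every aryl group on the aromatic carbon next to the ring nitrogen. In this assay, putting 2,5-dimethoxyphenyl in place of 3-fluorophenyl gives an at least 36-fold higher number from compound 2 to compound 3 (1.55 log units; beyond the scatter) and so a large loss of inhibition, the first measured sign that this assay responds strongly to a change at this position. The reading for compound 3 is a limit and not a number: the limit of > 105 nM in this assay, at which 1 of the 3 values shown sits.

Compound 3 brings in both methoxy groups and removes the fluorine in a single step, and the compounds shown do not reveal which of these differences matters, or whether both do. A phenyl ring carrying a single methoxy group or a hydroxyl group at this position would help to separate them.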